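The source may hold more compounds than are shown below. What is called first, only, known or untested is meant among the compounds shown, and "the series" means these compounds.

In a functional assay on the whole organism (Abdomen, strain Swiss) for inhibition, with Mus musculus as the target, with stated times of 30 min, 10 min and 5 min, at a dose of 40 mg/kg by the oral route (on this read-out higher numbers stand for a stronger effect at the one dose given and lower numbers for a weaker effect), compound 1 `COc1cccc(N2CCN(CCCn3nc(-c4ccccc4)c(C#N)c3C)CC2)c1` gives 34%. Compound 2 `Cc1ccc(N2CCN(CCCn3nc(-c4ccccc4)c(C#N)c3C)CC2)cc1` differs from it in one place, (4-methylphenyl in place of 3-methoxyphenyl on an amine nitrogen in a ring), and in this assay compound 2 gives 30%; the step is a number 4 percentage points lower from compound 1 to compound 2 (within the scatter). Compound 3 `COc1cccc(N2CCN(CCCn3cccc3C(C)=O)CC2)c1` is built on another core, and the difference between the two cores is not broken down here; in this assay compound 3 gives 52%, the highest of the three numbers, and its distance from compound 1 and from compound 2 lies beyond the scatter. Compound 4 `CC(=O)c1cccn1CCCN1CCN(c2ccc(C)cc2)CC1` carries the same change on the core of compound 3: 4-methylphenyl in place of 3-methoxyphenyl on an amine nitrogen in a ring. The place is the same word for word in both pairs, so this is the same change made twice. Among the measured compounds shown here, its only earlier instance, from compound 1 to compound 2, lay within the scatter, and nothing among the three measured compounds suggests that the core of compound 3 answers it differently. The expected step here is therefore a number 4 percentage points lower from compound 3 to compound 4 (within the scatter), of the same small size as the earlier one. Compound 4 is estimated to give 48%, most likely between 36% and 60%.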

Compound 4, a percentage reported as inhibition, in the whole organism at one dose (the size of the read-out at that dose, not a potency): 9%
For compound 4 the middle estimate is 39 percentage points above the measured one; the whole stated range lies above it.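

In this assay the exchange of 3-methoxyphenyl for 4-methylphenyl gives a number 43 percentage points lower from compound 3 to compound 4 (beyond the scatter), and the two cores do not answer this change alike: the same change on two cores in this assay, a number 4 percentage points lower (within the scatter) from compound 1 to compound 2 and a number 43 percentage points lower (beyond the scatter) from compound 3 to compound 4, 39 percentage points apart, beyond the scatter of two such steps

The size of the step on the core of compound 1 therefore cannot be carried over to the core of compound 3 in this series. This rests on a single pair on each core at one dose, and it shows neither why the cores differ nor whether any other change on the same amine nitrogen would depend on the core in the same way.

The change alters both the group and where it stands on the phenyl ring, so the compounds shown cannot separate the two; a 3-methylphenyl or a 4-methoxyphenyl on the core of compound 3 would do so. Also open, on these data alone, is whether the gap between the cores persists with an unsubstituted phenyl on that nitrogen or with a longer chain to the piperazine-bearing side.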